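A few compounds are considered here, and "the series" means these few. Any claim that something is new, unique, unknown or untested is made for them only; others in the source may bear on it.

Of the compounds shown here, two built on one shared core have been tested in a functional assay on BT-549 cells (Homo sapiens) for inhibition, read by sulforhodamine B assay, with a stated time of 48 h; a lower number here means a stronger inhibitor of growth, a higher number a weaker inhibitor of growth. Compound 1, `COc1cc2cc(Oc3ccc(NC(=O)Nc4cccc(C(F)(F)F)c4)cc3)c(C)nc2cc1OC`, gives 1430 nM. Compound 2, `COc1cc2cc(Oc3ccc(NC(=O)Nc4ccc(Cl)c(C(F)(F)F)c4)cc3)c(C)nc2cc1OC`, gives 981 nM, which is the lower of the two numbers. The step of a 1.5-fold lower number from compound 1 to compound 2 (0.16 log units; within the scatter) lies within the scatter, so the two compounds cannot really be told apart. Compound 3, `COc1cc2cc(Oc3ccc(NC(=O)Nc4ccc(Cl)c(Cl)c4)cc3)c(C)nc2cc1OC`, has not yet been measured. It differs from compound 2 in one place: chloro in place of trifluoromethyl on an aromatic carbon. Going by the values given here, the only measured step, a 1.5-fold lower number from compound 1 to compound 2 (0.16 log units; within the scatter), concerns a different group at a different position and was small, so it gives little guidance, and nothing seen so far points to a change beyond the scatter. For compound 3 the step expected is a 1.2-fold higher number from compound 2 to compound 3 (0.09 log units; within the scatter), that is, no shift beyond the scatter. Compound 3 is therefore estimated at 1200 nM, most likely between 500 nM and 3000 nM.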

Compound 3, concentration for 50% growth inhibition: 2400 nM
For compound 3 the middle estimate is 2.0-fold (0.30 log units) below the measured one; low and high end bracket the measured number.
By their numbers in this assay, from the lowest: compounds 2, 1 and 3 (each within the scatter of the next, the first and the last beyond it).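

In this assay, going by these compounds alone, replacing trifluoromethyl with chloro gives the first step to pass beyond the scatter, a 2.4-fold higher number from compound 2 to compound 3 (0.39 log units; beyond the scatter), so this position, ortho to a chloro group, responds modestly to the group placed on it. The wider comparison, 3,4-dichlorophenyl in place of 3-(trifluoromethyl)phenyl, gives a 1.7-fold higher number from compound 1 to compound 3 (0.22 log units; within the scatter), which lies within the scatter, so compound 1 and compound 3 cannot be told apart, and the effect seen here is limited to the pair compound 2 and compound 3. Nothing available explains why this exchange shifts the number. Still open, on these data alone, is how a nitrile, a methoxy group or an amine would behave at this position. The compounds shown also leave open whether the same exchange would give a similar step on a ring without the chloro group.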